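This account rests on a few compounds, and the source may have more. Where it says the series, first, only, none or still open, it means among the compounds named here.

Compound 1 `Cc1ccccc1-n1cc(-c2ccccc2)c(-c2ccc3c(c2)NC(=O)CO3)n1`: 62.9%
Compound 2 `O=C1COc2ccc(-c3nn(-c4ccc(Br)cc4)cc3-c3ccccc3)cc2N1`: 54.2%
Compound 3 `O=C1COc2ccc(-c3nn(-c4ccc(F)cc4)cc3-c3ccccc3)cc2N1`: 45.2%

In a functional assay on DLD-1 cells (Homo sapiens) for cytotoxicity, read by colorimetric assay and MTT assay, with a stated time of 3 days, tested at 20 uM (a lower number here means a stronger effect, a higher number a weaker effect of the compound at the concentration tested), compound 3 stands at the lowest of the three numbers, though its gap to compound 2 is within the scatter, so the two cannot be ordered; only the gap to compound 1 is beyond it, as a number 17.7 percentage points lower from compound 1 to compound 3 (beyond the scatter) shows. Compound 4 `O=C1COc2ccc(-c3nn(-c4cc(Cl)cc(Cl)c4)cc3-c3ccccc3)cc2N1` carries 3,5-dichlorophenyl in place of 4-fluorophenyl on an aromatic nitrogen. The measured steps that bear on this are the two aryl exchanges on the aromatic nitrogen, a number 8.7 percentage points lower from compound 1 to compound 2 (within the scatter) and a number 17.7 percentage points lower from compound 1 to compound 3 (beyond the scatter), and the halogen swap a number 9 percentage points lower from compound 2 to compound 3 (within the scatter), of which only the 2-methylphenyl to 4-fluorophenyl exchange moved beyond the scatter. Among the measured compounds shown here, no measured step involves a 3,5-dichlorophenyl group, so the expectation rests on the halophenyl pair alone. Because the halogen swap a number 9 percentage points lower from compound 2 to compound 3 (within the scatter) stayed within the scatter, compound 4 is expected to land close to compound 3, with a step of a number 0.2 percentage points lower from compound 3 to compound 4 (within the scatter) in this assay that need not exceed the scatter. Compound 4 is therefore estimated at 45%, within 30% to 62%.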

Compound 4, a percentage reported as activity, at one concentration (the size of the read-out at that concentration, not a potency): 52.2%
Compound 4: middle estimate off by 7.2 percentage points, on the low side; measured number inside the range.
By their numbers in this assay, from the lowest: compounds 3, 4, 2 and 1 (each within the scatter of the next, the first and the last beyond it).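

In this assay, the 3,5-dichlorophenyl group on the aromatic nitrogen cannot be told apart from either of the other two halophenyl groups (a number 7 percentage points higher from compound 3 to compound 4 (within the scatter); a number 2 percentage points lower from compound 2 to compound 4 (within the scatter)), so adding a second halogen and changing its place on the ring gave no readable change among these compounds. The 3,5-dichlorophenyl group joins 4-fluorophenyl in standing beyond the scatter from 2-methylphenyl (a number 10.7 percentage points lower from compound 1 to compound 4 (beyond the scatter)), although compound 2, with 4-bromophenyl, goes against a clean split between halophenyl and 2-methylphenyl because its step from compound 1 stays within the scatter. Nothing measured here accounts for these differences.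

The compounds shown leave open whether a longer alkyl chain on this nitrogen, or a phenyl ring carrying an amine or a carboxylic acid, would separate from the halophenyl compounds. They also leave open how the phenyl group and the shared core, unchanged throughout, bear on the effect.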